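The source may report more compounds than this note shows. Statements on the series, on what has been measured and on what is new or still open speak of the compounds shown alone.

Measured so far in an ADME assay on microsomes from liver (Mus musculus) for metabolic stability, read by LC-MS, with a stated time of 40 min, tested at 0.5 uM; on this read-out lower numbers stand for slow clearance and higher numbers for fast clearance:

- Compound 1 `CC(C)(CO)S(=O)(=O)c1cccc(NC(=O)c2cccnc2N2CCC3(CC2)CC3)c1`: > 399 mL.min-1.g-1, a limit and not a number
- Compound 2 `CC(C)S(=O)(=O)c1cccc(NC(=O)c2cccnc2N2CCC3(CC2)CC3)c1`: > 399 mL.min-1.g-1, a limit and not a number
- Compound 3 `O=C(Nc1cccc(S(=O)(=O)C2COC2)c1)c1cccnc1N1CCC2(CC1)CC2`: 385 mL.min-1.g-1

Compound 3 is the only one of the three with an actual number, 385 mL.min-1.g-1. Compound 1 and compound 2 stand at the limit of > 399 mL.min-1.g-1 in this assay, at which 2 of the 3 values shown sit.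

The next compound is compound 4 `O=C(Nc1cccc(S(=O)(=O)N2CCCC2)c1)c1cccnc1N1CCC2(CC1)CC2`, which has pyrrolidin-1-yl in place of oxetan-3-yl on a sulfonyl sulfur. The closest guides are the two measured changes of the group on that same sulfur that end at compound 3. They are an at least 1.0-fold lower number from compound 1 to compound 3 (0.01 log units; that floor lies within the scatter) and an at least 1.0-fold lower number from compound 2 to compound 3 (0.01 log units; that floor lies within the scatter). On these data alone, both are only floors, set by a limit, so their true size stays open. The step that the two limits leave unreadable from compound 1 to compound 2 adds nothing that can be read. Among the compounds with values here, no measured compound carries pyrrolidin-1-yl, so the data give no direct view of this group.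

With the three values so close to the limit, the expected change is none beyond the scatter in this assay, and a further limit would be no surprise. The estimated step is a 1.1-fold lower number from compound 3 to compound 4 (0.04 log units; within the scatter). For compound 4 the expected value is 350 mL.min-1.g-1, with an estimated range of 200 mL.min-1.g-1 to 399 mL.min-1.g-1.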

Compound 4, intrinsic clearance in microsomes: > 399 mL.min-1.g-1
Compound 4: a limit, no number (the forecaster's own chance of this, stated with the estimate: 40%); at least 1.1-fold (0.05 log units) between middle value and limit.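

In this assay, a ring joined through its nitrogen, pyrrolidin-1-yl, now sits on the sulfonyl sulfur, and compound 4 still gives only a limit and not a number. Within the data shown here, the one readable comparison is an at least 1.0-fold higher number from compound 3 to compound 4 (0.01 log units; that floor lies within the scatter), so replacing oxetan-3-yl with pyrrolidin-1-yl shows no change that stands clear of the scatter, and the steps from compound 1 and from compound 2 to compound 4 cannot be read, as both ends of each are limits. Compound 4 therefore joins compound 1 and compound 2 at the same limit, which leaves compound 3 as the only compound with an actual number: the limit of > 399 mL.min-1.g-1 in this assay, at which 3 of the 4 values shown sit.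

On these data alone, how far compound 4 truly lies from compound 3 stays open, since a limit hides the real size of the step. Also open, as far as these compounds go, is whether another group on the sulfonyl sulfur, such as morpholin-4-yl or a plain methyl, or a change elsewhere on the shared core, would bring the read-out clearly down from the value of compound 3, 385 mL.min-1.g-1.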